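Ring swap at the second amide of the shared core

The source may report more compounds than this note shows. Statements on the series, on what has been measured and on what is new or still open speak of the compounds shown alone.

compound 1: `O=C(Cc1ccccn1)N[C@H]1CCC[C@H](NC(=O)c2cccc(Cl)c2)C1`, > 10000 nM
compound 2: `O=C(N[C@H]1CCC[C@H](NC(=O)c2ccccn2)C1)c1cccc(Cl)c1`, > 10000 nM

In a functional assay on HEK293 cells for antagonist activity at metabotropic glutamate receptor 5 (Homo sapiens), read by FLIPR and calcium flux (on this read-out lower numbers stand for stronger inhibition and higher numbers for weaker inhibition), compound 1 gives > 10000 nM, which is a limit of the assay and not a number. Compound 2 likewise stops at a limit, > 10000 nM. The step that the two limits leave unreadable from compound 1 to compound 2 is thus unreadable, and compound 2 sits at the limit of > 10000 nM in this assay, at which 2 of the 2 values shown sit. Compound 3 `O=C(N[C@H]1CCC[C@H](NC(=O)c2ccccc2F)C1)c1cccc(Cl)c1` carries 2-fluorophenyl in place of pyridin-2-yl on a carbonyl carbon. Among the compounds with values here, no measured step speaks to this change, as both anchors are limits. The step that the limit leaves unreadable from compound 2 to compound 3 is expected to stay within the scatter. Compound 3 is therefore estimated at 20000 nM, with a range from 3000 nM to 100000 nM.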

Compound 3, half-maximal inhibitory concentration: 175 nM
Compound 3: middle estimate off by 110-fold (2.06 log units), on the high side; the whole stated range lies above it.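

On this carbonyl carbon, the change to 2-fluorophenyl is not neutral: it gives an at least 57-fold lower number from compound 2 to compound 3 (1.75 log units; beyond the scatter), and an at least 57-fold lower number from compound 1 to compound 3 (1.75 log units; beyond the scatter). Both sizes are floors, since each starts from a limit. Compound 3 alone among the three gives a readable number in this assay: the limit of > 10000 nM in this assay, at which 2 of the 3 values shown sit.

Still open, on these data alone, is whether a plain phenyl or a 2-methoxyphenyl on this carbonyl carbon would match compound 3. The compounds shown therefore do not separate the part played by the fluorine from that of the carbon-only ring.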